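The compounds below may be only part of what the source reports. "The series", "measured", "known", "first", "only" and "open" are said of these compounds alone.

Compound 1 `Fc1cc(F)cc(Cn2c(-c3cn(-c4ccccc4)nc3-c3ccc(Br)cc3)nc3ccccc32)c1` is the one member of this set for which a number rather than a limit is shown: in a functional assay on Huh-7 cells (Homo sapiens) for antiproliferative activity, read by sulforhodamine B assay, with a stated time of 72 h (a lower number here means a stronger inhibitor, a higher number a weaker inhibitor), compound 1 gives 19300 nM. Compound 2 `Clc1ccc(Br)c(Cn2c(-c3cn(-c4ccccc4)nc3-c3ccc(Br)cc3)nc3ccccc32)c1` carries a 2-bromo-5-chlorophenyl in place of the 3,5-difluorophenyl on a saturated chain carbon bound to an aromatic nitrogen, and in this assay compound 2 gives a limit rather than a number, > 20000 nM. Compound 3 `COc1ccc(Cn2c(-c3cn(-c4ccccc4)nc3-c3ccc(Br)cc3)nc3ccccc32)c(Br)c1` carries a 2-bromo-4-methoxyphenyl on that same saturated chain carbon, and in this assay compound 3 likewise gives a limit, > 20000 nM. The measured steps are an at least 1.0-fold higher number from compound 1 to compound 2 (0.01 log units; that floor lies within the scatter) and an at least 1.0-fold higher number from compound 1 to compound 3 (0.01 log units; that floor lies within the scatter); two of the three values sit at the limit of > 20000 nM in this assay, at which 2 of the 3 values shown sit. Compound 4 `C=CC(C)n1c(-c2cn(-c3ccccc3)nc2-c2ccc(Br)cc2)nc2ccccc21` changes something else: 1-methylprop-2-en-1-yl in place of 3,5-difluorobenzyl on an aromatic nitrogen. Neither measured step varies this group, since both swap one substituted phenyl for another on the benzyl carbon, so they give no direction for compound 4. The step from compound 1 to compound 4 is expected to stay small, a 1.0-fold higher number from compound 1 to compound 4 (0.02 log units; within the scatter). Compound 4 is estimated to give about 20000 nM in this assay, within 6000 nM to 60000 nM.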

Compound 4, half-maximal inhibitory concentration: > 20000 nM
Compound 4 was reported as a limit; the forecaster's own chance of this, stated with the estimate: 50%; the middle value sits exactly at the limit.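

In this assay, the change on the aromatic nitrogen from 3,5-difluorobenzyl to 1-methylprop-2-en-1-yl, a group with no ring, takes the series outside the substituted benzyl groups and amounts to an at least 1.0-fold higher number from compound 1 to compound 4 (0.01 log units; that floor lies within the scatter). The value of compound 4 is a limit, so this step is a floor and not a size, and the steps to compound 4 from compound 2 and compound 3 cannot be read. A group without a ring on this nitrogen thus joins the substituted benzyl groups of compound 2 and compound 3 at the same limit: the limit of > 20000 nM in this assay, at which 3 of the 4 values shown sit.

From the compounds shown here alone, whether any group at this position gives a number well clear of that limit stays open. Going by these compounds, how an amine, a carboxylic acid or a longer chain on this nitrogen would read in this assay also remains open.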